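Swapping the ketone aryl group on a pyrazole chalcone scaffold

The compounds below may be only part of what the source reports. "The series", "measured", "known", "first", "only" and "open" are said of these compounds alone.

Compound 2 `O=C(/C=C/c1cn(-c2ccccc2)nc1-c1ccncc1)c1cc[nH]c1` gives 13600 nM in a functional assay on MCF7 cells (Homo sapiens) for inhibition, read by sulforhodamine B assay, with a stated time of 72 h (on this read-out higher numbers stand for weaker inhibition and lower numbers for stronger inhibition), the highest of the two numbers recorded, while compound 1 `COc1ccc(OC)c(C(=O)/C=C/c2cn(-c3ccccc3)nc2-c2cccnc2)c1` gives 1500 nM in this assay. Compound 3 `COc1ccc(OC)c(C(=O)/C=C/c2cn(-c3ccccc3)nc2-c2ccncc2)c1` differs from compound 2 by 2,5-dimethoxyphenyl in place of 1H-pyrrol-3-yl on a carbonyl carbon. For the measured compounds named here, no measured pair covers this exact change, but compound 3 shares its 2,5-dimethoxyphenyl group on the carbonyl carbon with compound 1, whose 1500 nM sits well lower. A large step toward stronger inhibition is therefore expected a 5.4-fold lower number from compound 2 to compound 3 (0.74 log units; beyond the scatter). Compound 3 is estimated at 2500 nM, with a range from 800 nM to 8000 nM.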

Compound 3, half-maximal inhibitory concentration: 1400 nM
The estimate for compound 3 lay 1.8-fold (0.25 log units) above the measured number; the range from low to high includes it.
By their numbers in this assay, from the lowest: compounds 3 and 1 (each within the scatter of the next); then compound 2.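

On the carbonyl carbon, 2,5-dimethoxyphenyl in place of 1H-pyrrol-3-yl now has a directly measured step in this assay: a 9.7-fold lower number from compound 2 to compound 3 (0.99 log units; beyond the scatter). With 2,5-dimethoxyphenyl on that carbon, pyridin-4-yl in place of pyridin-3-yl on an aromatic carbon leaves the two compounds indistinguishable, a 1.1-fold lower number from compound 1 to compound 3 (0.03 log units; within the scatter). Nothing available explains either result.

The compounds shown leave open whether a plain phenyl or a phenyl carrying a single methoxy group on the carbonyl carbon would give the same step. They also leave open whether the pyridine swap would remain this small with 1H-pyrrol-3-yl on that carbon.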